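Methoxy to hydroxy on a pyrazole-linked aryl nitrile series

The compounds below may be only part of what the source reports. "The series", "measured", "known", "first", "only" and "open" are said of these compounds alone.

Three compounds share one core and are measured in a functional assay on SK-OV-3 cells (Homo sapiens) for inhibition, read by sulforhodamine B assay, with a stated time of 48 h; on this read-out lower numbers stand for higher toxicity in this test and higher numbers for lower toxicity in this test. Compound 1 `COc1cc(C)cc(-c2c(-c3ccnc(-c4ccc(C(C)=O)cc4)c3)cnn2CC#N)c1` reaches only a limit of the assay, giving > 100000 nM. Compound 2 `Cc1cc(O)cc(-c2nn(CC#N)cc2-c2ccnc(-c3ccc(Oc4ccccc4)cc3)c2)c1`, which carries a hydroxy group in place of a methoxy group and a phenoxy group at the far end, gives a number in this assay, 49600 nM. Compound 3 `COc1cc(C)cc(-c2nn(CC#N)cc2-c2ccnc(-c3ccc(N(C)C)cc3)c2)c1` again sits at a limit of the assay in this assay, at > 100000 nM. Compound 3 thus stands at the limit of > 100000 nM in this assay, at which 2 of the 3 values shown sit, so its position relative to the other two cannot be fixed beyond saying that compound 2 gave a measurable value while compound 3 did not.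

Compound 4 `Cc1cc(O)cc(-c2nn(CC#N)cc2-c2ccnc(-c3ccc(N(C)C)cc3)c2)c1` has not yet been measured in this assay. It differs from compound 3 by hydrogen in place of methyl on an oxygen on an aromatic ring. Of the measured compounds, only compound 2, which bears the hydroxy group, returned a number, while compounds 1 and 3, both bearing the methoxy group, returned limits.

On that basis the step from compound 3 to compound 4 is expected to move toward higher toxicity, though its size is uncertain because compound 3 sits at > 100000 nM, a limit and not a number; the expected step is an at least 1.2-fold lower number from compound 3 to compound 4 (0.09 log units; that floor lies within the scatter). For compound 4 the estimated value in this assay is 80000 nM, expected to lie between 30000 nM and 200000 nM.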

Compound 4, concentration lethal to 50% of the cells: > 100000 nM
Compound 4 ended at the assay's limit; the forecaster's own chance of this, stated with the estimate: 45%; at least 1.2-fold (0.09 log units) between middle value and limit.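

In this assay, compound 4 carries the hydroxy group and still sits at a limit of the assay, so hydroxy in place of methoxy no longer goes with a measured number in every case. The step between the two compounds that differ at this oxygen cannot be read, as both ends of it are limits, and no size can be given to the change from 3-methoxy-5-methylphenyl to 3-hydroxy-5-methylphenyl. With the hydroxy group held constant, dimethylamino in place of phenoxy on an aromatic carbon gives an at least 2.0-fold higher number from compound 2 to compound 4 (0.30 log units; that floor lies within the scatter), which makes the far end of the molecule a second place to watch, while most of the set stays at one ceiling: the limit of > 100000 nM in this assay, at which 3 of the 4 values shown sit.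

Going by these compounds, whether methoxy in place of hydroxy would shift the number when phenoxy stands at the far end remains open. Also open, on these data alone, is whether an amine or a carboxylic acid at that far end, or a longer chain on the oxygen, would bring a number in this assay.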